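A few compounds are considered here, and "the series" means these few. Any claim that something is new, unique, unknown or untested is made for them only; others in the source may bear on it.

All three measured compounds were tested in a functional assay on NCI-H460 cells (Homo sapiens) for cytotoxicity, read by MTT assay, with a stated time of 48 h; on this read-out lower numbers stand for stronger inhibition and higher numbers for weaker inhibition:

compound 1, `COc1cc(/C=C/C(=O)/C=C/c2nc3cc(Cl)ccc3n2C)ccc1O`, gives 8900 nM;
compound 2, `COc1cc(/C=C/C(=O)/C=C/c2nc3cc([N+](=O)[O-])ccc3n2C)ccc1O`, gives 6700 nM;
compound 3, `COc1ccc(/C=C/C(=O)/C=C/c2nc3cc(Cl)ccc3n2C)cc1O`, gives 7300 nM.

A fourth member of the series, compound 4, `COc1ccc(/C=C/C(=O)/C=C/c2nc3cc([N+](=O)[O-])ccc3n2C)cc1O`, has not yet been measured.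

Compound 2 differs from compound 1 by nitro in place of chloro on an aromatic carbon. In this assay that change produced a 1.3-fold lower number from compound 1 to compound 2 (0.12 log units; within the scatter), so the two numbers cannot be told apart with confidence. Compound 3 is built from the same atoms as compound 1 but joined differently; the difference between the two cores is not broken down here. Compound 3 and compound 2 give numbers that are also within the scatter of each other, as are compound 3 and compound 1, so the three measured values sit in one narrow band.

Compound 4 differs from compound 3 by nitro in place of chloro on an aromatic carbon. For the measured compounds named here, this is the same change, at the same place on the same kind of ring, as the one that turned compound 1 into compound 2. For compound 4 the step from its parent is expected to be a 1.3-fold lower number from compound 3 to compound 4 (0.10 log units; within the scatter), because the same change gave a 1.3-fold lower number from compound 1 to compound 2 (0.12 log units; within the scatter). Compound 4 is therefore expected to give about 5800 nM in this assay. The estimate for compound 4 should most likely fall between 2900 nM and 11600 nM.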

Compound 4, half-maximal inhibitory concentration: 10500 nM
For compound 4 the middle estimate is 1.8-fold (0.26 log units) below the measured one, and the stated range covers the measured number.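

On the core of compound 3, nitro in place of chloro gives a 1.4-fold higher number from compound 3 to compound 4 (0.16 log units; within the scatter) in this assay, and with nitro kept, 3-hydroxy-4-methoxyphenyl in place of 4-hydroxy-3-methoxyphenyl gives a 1.6-fold higher number from compound 2 to compound 4 (0.20 log units; within the scatter). Set beside the earlier step, the chloro-to-nitro change shows no difference between the two cores that can be told apart from ordinary measurement noise: the same change on two cores in this assay, a 1.3-fold lower number (0.12 log units; within the scatter) from compound 1 to compound 2 and a 1.4-fold higher number (0.16 log units; within the scatter) from compound 3 to compound 4, 1.9-fold (0.28 log units) apart, within the scatter of two such steps. This shows that the swap made no clear difference to the number on either core, but it does not show that the two steps are truly identical, and neither step is large enough to give the change a reliable direction or to predict its effect on a third core.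

The compounds shown carry only chloro or nitro at this place on the ring, so it remains open whether a different group there, such as an amine or a carboxylic acid, would shift the number beyond the scatter. They also offer only two arrangements of the hydroxy and methoxy groups on the phenyl ring, leaving open what a phenyl ring with two methoxy groups would do.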